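The compounds below may be only part of what the source reports. "The series", "measured", "known", "first", "only" and "open" are said of these compounds alone.

Measured so far in an ADME assay for permeability, using PAMPA, with a stated time of 30 min, at pH 7.4; a higher number here means that the compound crosses the layer faster, a lower number that the compound crosses the layer more slowly:
compound 1 `c1ccc(Oc2ccc3c(NCCCNCc4ccco4)ccnc3c2)cc1` gives 317 10^-6 cm/s;
compound 2 `COc1ccc(Oc2ccc3c(NCCCNCc4cccc(OC)c4O)ccnc3c2)cc1` gives 317 10^-6 cm/s;
compound 3 `COc1cccc(CNCCCNc2ccnc3cc(Oc4ccccc4)ccc23)c1O` gives 317 10^-6 cm/s.

Compound 3 stands level with both of the others: the step of no change at the digits printed from compound 1 to compound 3 (within the scatter) and the step of no change at the digits printed from compound 2 to compound 3 (within the scatter) both lie within the usual scatter, so the three compounds cannot be told apart on these numbers.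

Compound 4 `COc1cccc(CNCCCNc2ccnc3cc(CC4CCCCC4)ccc23)c1O` differs from compound 3 in one place: cyclohexylmethyl in place of phenoxy on an aromatic carbon. For the measured compounds named here, neither measured step touches this part of the shared core, and none swaps an aromatic ring for a non-aromatic one, so no step here can be carried over directly. Given that all three measured compounds sit at one level in this assay , the expectation is a step of no change at the digits printed from compound 3 to compound 4 (within the scatter), none beyond the scatter. Compound 4 is therefore estimated at 317 10^-6 cm/s, within 150 10^-6 cm/s to 500 10^-6 cm/s.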

Compound 4, apparent permeability: 23 10^-6 cm/s
Compound 4: middle estimate off by 14-fold (1.14 log units), on the high side; measured number outside the range, below it.
By their numbers in this assay, from the lowest: compound 4; then compounds 1, 2 and 3 (each within the scatter of the next).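

In this assay, this position proves sensitive: cyclohexylmethyl in place of phenoxy gives a 14-fold lower number from compound 3 to compound 4 (1.14 log units; beyond the scatter), and in place of 4-methoxyphenoxy it gives a 14-fold lower number from compound 2 to compound 4 (1.14 log units; beyond the scatter). For the compounds shown here, these are the first steps in the set beyond the scatter, as the two earlier changes, at the furan-2-yl group and at a methoxy group, left the read-out level. Nothing available here explains this fall.

The swap removes both an oxygen and an aromatic ring, so the compounds shown cannot separate the two. Benzyl, which keeps the aromatic ring without the oxygen, and cyclohexyloxy, which keeps the oxygen on a non-aromatic ring, would pull them apart.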